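Phenylsulfanyl in place of phenoxy: working notes

The source may report more compounds than this note shows. Statements on the series, on what has been measured and on what is new or still open speak of the compounds shown alone.

compound 1 (`O=C(O)c1cc(=O)c2cc(CCCCCc3ccccc3)ccc2o1`): 4.5 ug/mL
compound 2 (`O=C(O)c1cc(=O)c2ccc(OCCCCCOc3ccccc3)cc2o1`): 0.4 ug/mL

Both values come from a functional assay on ileum (Cavia porcellus) for antagonist activity, with a stated time of 30 s; a lower number here means a stronger inhibitor, a higher number a weaker inhibitor. Compound 2 has the lower of the two numbers, and its gap to compound 1 lies beyond the scatter. Among the measured compounds shown here, no measured pair yet differs in one place only.

Compound 3 (`O=C(O)c1cc(=O)c2ccc(OCCCCCSc3ccccc3)cc2o1`) is still unmeasured. Its change from compound 2 (phenylsulfanyl in place of phenoxy on a saturated chain carbon, five bonds along the chain from an oxygen on an aromatic ring) is phenylsulfanyl in place of phenoxy on a saturated chain carbon, five bonds along the chain from an oxygen on an aromatic ring. For the measured compounds named here, with no measured precedent for this swap, the expectation starts from compound 2 at 0.4 ug/mL and leans slightly towards a higher number in this assay. The expected size is an estimated step (a 1.5-fold higher number from compound 2 to compound 3 (0.18 log units; within the scatter)), not beyond the scatter. Compound 3 is estimated at 0.6 ug/mL (expected range 0.2 ug/mL to 2 ug/mL).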

Compound 3, half-maximal inhibitory concentration: 0.4 ug/mL
Estimate against measurement, compound 3: 1.5-fold (0.18 log units) above, within the range that was stated.
By their numbers in this assay, from the lowest: compounds 2 and 3 (each within the scatter of the next); then compound 1.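

Phenylsulfanyl in place of phenoxy on a saturated chain carbon, five bonds along the chain from an oxygen on an aromatic ring, gives no change at the digits printed from compound 2 to compound 3 (within the scatter) in this assay. Among the compounds shown here, this is the first comparison that differs in one place only, and in this read-out compound 2 and compound 3 cannot be told apart. The heavy-atom, donor and acceptor counts of the two groups also match, and nothing measured here gives a reason for the result.

On these data alone, whether an amine in place of the phenylsulfanyl sulfur would match compound 3, or a longer chain would hold up with either group, stays open. Compound 1 differs from compound 2 and compound 3 in more than one place, so its gap to them cannot be assigned to any single feature.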